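Cytotoxicity in HepG2 cells: from a naphthyl to a methoxyphenoxy substituent

The source may report more compounds than this note shows. Statements on the series, on what has been measured and on what is new or still open speak of the compounds shown alone.

Measured compounds:
compound 1 `COc1ccc(F)cc1CNCCCNc1ccnc2cc(CCc3ccccc3)ccc12`: 4240 nM
compound 2 `COc1ccc(F)cc1CNCCCNc1ccnc2cc(CC(C)C)ccc12`: 2900 nM
compound 3 `COc1ccc(F)cc1CNCCCNc1ccnc2cc(-c3cccc4ccccc34)ccc12`: 16000 nM

In an ADME assay on HepG2 cells (Homo sapiens) for cytotoxicity, read by luminescence, CellTiter-Glo and ATP content, with a stated time of 72 h (on this read-out lower numbers stand for an effect already at smaller amounts and higher numbers for an effect only at larger amounts of compound), compound 3 stands at the highest of the three numbers. Its nearest neighbour is compound 1, reached by a 3.8-fold higher number from compound 1 to compound 3 (0.58 log units; beyond the scatter), and the furthest is compound 2, reached by a 5.5-fold higher number from compound 2 to compound 3 (0.74 log units; beyond the scatter). Compounds 1 and 2 lie close together, as a 1.5-fold lower number from compound 1 to compound 2 (0.16 log units; within the scatter) shows.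

Compound 4 `COc1ccc(F)cc1CNCCCNc1ccnc2cc(Oc3ccccc3OC)ccc12` has not yet been measured in this assay. It differs from compound 3 as follows: 2-methoxyphenoxy in place of naphthalen-1-yl on an aromatic carbon. Both measured steps that bear on this change are those in which naphthalen-1-yl enters, from compound 1 and from compound 2, and both gave modest rises beyond the scatter. Since the step to compound 4 removes naphthalen-1-yl again, but does not return to the benzyl or isobutyl groups of compounds 1 and 2, part of that rise is expected to be given back, and a 2.0-fold lower number from compound 3 to compound 4 (0.30 log units; within the scatter) is the step estimated here. Compound 4 is therefore expected to give about 8000 nM in this assay, within a range from 3000 nM to 20000 nM.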

Compound 4, half-maximal effective concentration: 6400 nM
For compound 4 the middle estimate is 1.3-fold (0.10 log units) above the measured one; the measured number falls inside the stated range.
By their numbers in this assay, from the lowest: compounds 2, 1 and 4 (each within the scatter of the next, the first and the last beyond it); then compound 3.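

In this assay, among the compounds shown here, the earlier compounds left naphthalen-1-yl as the one group standing apart at this position, and 2-methoxyphenoxy, with one aromatic ring in place of two and with hydrogen-bond acceptors, brings the number down (a 2.5-fold lower number from compound 3 to compound 4 (0.40 log units; beyond the scatter)), so the high number of compound 3 is not shared by every aromatic substituent here. The new group still differs from isobutyl (a 2.2-fold higher number from compound 2 to compound 4 (0.34 log units; beyond the scatter)) but cannot be told apart from phenethyl (a 1.5-fold higher number from compound 1 to compound 4 (0.18 log units; within the scatter)), which places it with the flexible phenethyl group rather than with naphthalen-1-yl on this read-out. Nothing at hand accounts for these steps, and no cause can be assigned to any of them.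

The compounds shown leave open whether the oxygen link, the methoxy group or the loss of the second aromatic ring carries the step, as all three change together; a plain phenyl or an unsubstituted phenoxy group would separate them. They also leave open how a group of another kind at this position, such as an amine or a carboxylic acid, would read in this cell assay.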